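One Flipped Stereocentre on the Chain of Compound 2

The source may report more compounds than this note shows. Statements on the series, on what has been measured and on what is new or still open speak of the compounds shown alone.

Compound 1 `CCCCCCC[C@H](CCO)n1cnc2c(Cl)ncnc21` gives 2930 nM 
Compound 2 `CCCCCCCC[C@@H](CCO)n1cnc2c(Cl)ncnc21` gives 2330 nM 

In a functional assay on SW480 cells (Homo sapiens) for antiproliferative activity, read by MTT assay, with a stated time of 48 h (a higher number here means a weaker inhibitor, a lower number a stronger inhibitor), compound 2 and compound 1 lie within the usual scatter of each other, so neither can be ranked above the other. Compound 3 `CCCCCCCC[C@H](CCO)n1cnc2c(Cl)ncnc21` has the same atoms and bonds as compound 2 and differs only in configuration as drawn: the two compounds have the same atoms and bonds and differ only in configuration as drawn: 1 of 1 stereo elements differ; a stereocentre at a saturated chain carbon is drawn S in compound 2 and R in compound 3 with a stereocentre at a saturated chain carbon drawn S in compound 2 and R in compound 3. For the measured compounds named here, no measured pair shows what such a change does. In this assay no shift beyond the scatter is expected, in either direction. The expected change is a 1.1-fold higher number from compound 2 to compound 3 (0.03 log units; within the scatter) and no more. For compound 3 the estimated value is 2500 nM with 1300 nM to 4800 nM as its range.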

Compound 3, half-maximal inhibitory concentration: 320 nM
Estimate against measurement, compound 3: 7.8-fold (0.89 log units) above; measured number outside the range, below it.
By their numbers in this assay, from the lowest: compound 3; then compounds 2 and 1 (each within the scatter of the next).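

In this assay, the configuration at this saturated chain carbon clearly matters: going from S to R gives a 7.3-fold lower number from compound 2 to compound 3 (0.86 log units; beyond the scatter). The source of this shift is a single one: the fact that compounds 2 and 3 differ only in the configuration as drawn. Compound 3 also stands apart in the listed step with a 9.2-fold lower number from compound 1 to compound 3 (0.96 log units; beyond the scatter), which puts methyl in place of hydrogen on a saturated chain carbon, eight bonds along the chain from an aromatic nitrogen.

From the compounds shown here alone, whether the R form keeps its edge with a longer chain, or with an amine on the shared core, stays open.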